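This account rests on a few compounds, and the source may have more. Where it says the series, first, only, none or still open, it means among the compounds named here.

In a functional assay on MCF7 cells (Homo sapiens) for antiproliferative activity, read by MTT assay, with a stated time of 72 h (on this read-out higher numbers stand for weaker inhibition and lower numbers for stronger inhibition), compound 1 `COc1ccc(/C=C2\S/C(=N\c3ccc(Cl)cc3)N(C)C2=O)cc1` gives 39300 nM and compound 2 `COc1ccc(/C=C2\S/C(=N\c3ccc(F)cc3)N(C)C2=O)cc1` gives 66500 nM. Among the measured compounds shown here, these two values lie within the scatter of each other, so compound 2 stands level with compound 1, the only other measured member of the series. The next change leads to compound 3 `COc1ccc(/C=C2\S/C(=N\c3ccc(OC)cc3)N(C)C2=O)cc1`: methoxy in place of fluoro on an aromatic carbon. This is methoxy in place of fluoro on an aromatic carbon, para to a large group. For the measured compounds named here, only one measured step bears on it, fluoro in place of chloro at that same place, and it involves no methoxy, so it is a loose guide. With a 1.7-fold higher number from compound 1 to compound 2 (0.23 log units; within the scatter) as that guide, no step beyond the scatter is expected in this assay, and neither direction is favoured. The estimated value for compound 3 is 50000 nM, with an expected range from 18000 nM to 130000 nM. This estimate means an expected 1.3-fold lower number from compound 2 to compound 3 (0.12 log units; within the scatter).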

Compound 3, half-maximal inhibitory concentration: > 100000 nM
Compound 3: no number, only a limit; the forecaster's own chance of this, stated with the estimate: 10%; middle value at least 2.0-fold (0.30 log units) from the limit.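

In this assay compound 3 gives > 100000 nM, which is a limit of the assay and not a number. Among the compounds shown here, at this place on the aromatic ring, methoxy in place of chloro gives an at least 2.5-fold higher number from compound 1 to compound 3 (0.40 log units; beyond the scatter), the first step here to pass the scatter, whereas methoxy in place of fluoro gives an at least 1.5-fold higher number from compound 2 to compound 3 (0.17 log units; that floor lies within the scatter), a floor that does not by itself separate the two compounds. Both steps are floors and not full sizes: the limit of > 100000 nM in this assay, at which 1 of the 3 values shown sits.

Still open, from the compounds shown here alone, is whether another group at this place, such as a hydroxyl, an amine or a carboxylic acid, would stay level with compound 1 or also shift towards weaker inhibition. Also open, going by these compounds, is how the methoxy of the shared core bears on these values, since all three compounds carry it unchanged.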